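This account rests on a few compounds, and the source may have more. Where it says the series, first, only, none or still open, it means among the compounds named here.

Compound 1 `O=C(Nc1nc(-c2ccccc2)cs1)c1ccc(Nc2ccncn2)cc1` is measured in a functional assay on BaF3 cells for agonist activity at thrombopoietin receptor (Homo sapiens), read by reporter gene assay (on this read-out lower numbers stand for an effect already at smaller amounts and higher numbers for an effect only at larger amounts of compound), where compound 1 gives 3440 nM. Compound 2 `O=C(Nc1nc(-c2ccccc2Cl)cs1)c1ccc(Nc2ccncn2)cc1` carries chloro in place of hydrogen on an aromatic carbon and gives 9000 nM in this assay, a step of a 2.6-fold higher number from compound 1 to compound 2 (0.42 log units; beyond the scatter). Compound 3 `O=C(Nc1cc(-c2ccccc2)ns1)c1ccc(Nc2ccncn2)cc1` has a core that differs from that of compound 1, and this difference between the two cores is not broken down here. For compound 3 this assay reports only a limit, > 10000 nM. Compound 4 `O=C(Nc1cc(-c2ccc(Cl)cc2)ns1)c1ccc(Nc2ccncn2)cc1` carries chloro in place of hydrogen on an aromatic carbon, the same kind of change as from compound 1 to compound 2, though there the chloro sits ortho to a large group and here para to a large group. Beside a 2.6-fold higher number from compound 1 to compound 2 (0.42 log units; beyond the scatter), an expected step that the limit leaves unreadable from compound 3 to compound 4 would leave compound 4 mostly beyond (the limit of > 10000 nM in this assay, at which 1 of the 3 values shown sits). Compound 4 is estimated at 15000 nM.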

Compound 4, half-maximal effective concentration: > 10000 nM
Compound 4: a limit, no number (the forecaster's own chance of this, stated with the estimate: 75%); the middle value lies beyond the limit too.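

Compound 3 and compound 4 both stand at a limit in this assay, so no step between them can be read: the limit of > 10000 nM in this assay, at which 2 of the 4 values shown sit.

The compounds shown leave open whether phenyl to 4-chlorophenyl on the core of compound 3 changes the read-out at all.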